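The compounds below may be only part of what the source reports. "The series", "measured", "known", "first", "only" and "open" are said of these compounds alone.

Measured so far:
- compound 1, `S=c1[nH]nc(Cc2ccc(Cl)cc2Oc2ccccc2Cl)[nH]1`: 159% in a functional assay on the whole organism (strain NMRI) with Mus musculus as the target, with a stated time of 60 min, at a dose of 20 mg/kg by the intraperitoneal route; a higher number here means a stronger effect of the compound at the dose given, a lower number a weaker effect
- compound 2, `CSc1nnc(Cc2ccccc2Oc2ccccc2)[nH]1`: 147% in this assay

Compound 1 gives the higher of the two numbers in this assay. For the measured compounds named here, its nearest neighbour is compound 2, whose number is lower by an amount beyond the usual scatter, so the two measured compounds are distinguished from each other; no single-point step connects them, and only the two values themselves are available.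

Compound 3, `CCOc1nnc(Cc2ccc(Cl)cc2Oc2ccccc2Cl)[nH]1`, is not yet measured. It differs from compound 1 at one place: a group of 8 heavy atoms (4 carbon, 3 nitrogen, 1 oxygen; one five-membered aromatic ring with 3 hetero atoms) in place of a group of 6 heavy atoms (2 carbon, 3 nitrogen, 1 sulfur; one five-membered aromatic ring with 3 hetero atoms), on a saturated chain carbon bound to an aromatic carbon. The shared core is otherwise retained. Going by the values given here, no measured pair in this small set shows how a change of this kind moves the read-out in this assay, so the expectation rests on the two values alone.

Given that both measured compounds sit in the same high region of this assay, a modest downward step is expected, a number 19 percentage points lower from compound 1 to compound 3 (beyond the scatter), although a result within the scatter of compound 1 would also be unsurprising. For compound 3 the estimated activity in this assay is 140%, with a range from 105% to 175%.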

Compound 3, a percentage reported as activity, at one dose (the size of the read-out at that dose, not a potency): 135%
Compound 3: the middle estimate sits 5 percentage points above what was measured; the measured number falls inside the stated range.
By their numbers in this assay, from the lowest: compound 3; then compound 2; then compound 1.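

For the compounds shown here, compound 3 gives the first step in this set that changes one place only: on a saturated chain carbon bound to an aromatic carbon, the group of 8 heavy atoms (4 carbon, 3 nitrogen, 1 oxygen) in place of the group of 6 heavy atoms (2 carbon, 3 nitrogen, 1 sulfur) gives a number 24 percentage points lower from compound 1 to compound 3 (beyond the scatter) in this assay. The read-out at this place therefore responds to the change, yet the step is modest and compound 3 still gives 135% at the single dose tested, so the change lowers the number without removing the effect. No measured property of either group accompanies this step, and the reason for it stays unexplained.

One step cannot show whether the direction or size seen here is specific to these two groups, or whether an amine, a carboxylic acid or a longer chain in the same place would lower the number further or restore it. It also leaves open whether the same exchange would move the read-out similarly on a core without the two chlorine atoms, and how the numbers would behave at other doses.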